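A Carboxyphenyl Group Takes the Place of Benzyl

The source may report more compounds than this note shows. Statements on the series, on what has been measured and on what is new or still open speak of the compounds shown alone.

In an ADME assay on S9 fraction from liver (Rattus norvegicus) for metabolic stability, read by LC-MS, using NADPH, with a stated time of 30 min (on this read-out higher numbers stand for a more stable compound and lower numbers for a less stable compound), compound 3 `CCCCCCCCc1ccc(OCC(=O)Cn2nnnc2Cc2ccccc2)cc1` gives 26%. Compound 2 `CCCCCCCCc1ccc(OCC(=O)Cn2nnnc2-c2cccs2)cc1` gives 27%, and a number 1 percentage points lower from compound 2 to compound 3 (within the scatter), so these two values cannot be told apart. Compound 1 `CCCCCCCCc1ccc(OCC(=O)Cn2nnnc2-c2ccccn2)cc1` gives < 5%, which is a limit of the assay and not a number. Against that limit, the other two compounds show a number at least 22 percentage points higher from compound 1 to compound 2 (beyond the scatter) and a number at least 21 percentage points higher from compound 1 to compound 3 (beyond the scatter). These sizes are bounded from one side only, as the limit of < 5% in this assay, at which 1 of the 3 values shown sits, makes plain.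

Compound 4 `CCCCCCCCc1ccc(OCC(=O)Cn2nnnc2-c2ccc(C(=O)O)cc2)cc1` carries 4-carboxyphenyl in place of benzyl on an aromatic carbon. Among the measured compounds shown here, no measured compound carries this group, so the three steps at this same place are the only guide. The level pair of compound 2 and compound 3, at a number 1 percentage points lower from compound 2 to compound 3 (within the scatter), suggests that a change here need not move the result. The step to compound 1, seen in a number at least 21 percentage points higher from compound 1 to compound 3 (beyond the scatter), shows that it can move it beyond the scatter. No step beyond the scatter is therefore expected, and no direction is favoured, although the uncertainty is wide. The expected change is a number 1 percentage points lower from compound 3 to compound 4 (within the scatter). In this assay, the estimate for compound 4 is 25%, with an expected range from 6% to 55%.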

Compound 4, percent of the compound remaining: 6%
Beside the measured number, compound 4's estimate is 19 percentage points above it; the measured number falls inside the stated range.
By their numbers in this assay, from the lowest: compound 4; then compounds 3 and 2 (each within the scatter of the next). At a limit, below all of these: compound 1.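

In this assay, 4-carboxyphenyl at this place gives steps whose two ends are both numbers, a number 20 percentage points lower from compound 3 to compound 4 (beyond the scatter) and a number 21 percentage points lower from compound 2 to compound 4 (beyond the scatter). Among the compounds shown here, until now, the only steps beyond the scatter at this aromatic carbon, between two ring nitrogen atoms, ran against a limit, while benzyl and thiophen-2-yl stood level, so the size of a change here can now be read on both sides. Compound 1 stands at a limit of the assay and not at a number. Against that limit the remaining step reads a number at least 1 percentage points higher from compound 1 to compound 4 (that floor lies within the scatter), so it is bounded from one side only and the order of these two compounds stays unsettled: the limit of < 5% in this assay, at which 1 of the 4 values shown sits.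

The compounds shown leave open whether the change follows the carboxylic acid itself or the phenyl ring set directly on the core, which an unsubstituted phenyl group, a methyl ester or an amine on that ring would separate. They also leave open whether the same step would appear with a shorter chain in place of the octyl chain.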